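Hydroxy for Amino: A Carboxy Analogue of a Pyridine Acrylamide

A few compounds are considered here, and "the series" means these few. Any claim that something is new, unique, unknown or untested is made for them only; others in the source may bear on it.

Measured compounds:
compound 1 `NC(=O)/C=C/c1ccncc1-c1ccc2ccccc2c1` — 10.5 nM
compound 2 `Cn1ncc2cc(-c3cnccc3/C=C/C(=O)N3CCOCC3)ccc21` — 356 nM

In an assay on a protein complex for inhibition of CDK8/Cyclin C (Homo sapiens), with a stated time of 1 h (a lower number here means a stronger inhibitor, a higher number a weaker inhibitor), compound 1 gives 10.5 nM, the lowest of the two numbers shown, and compound 2 gives 356 nM, a weaker result that lies beyond the scatter. Compound 3 `O=C(O)/C=C/c1ccncc1-c1ccc2ccccc2c1` has not yet been measured. It differs from compound 1 in one place: hydroxy in place of amino on a carbonyl carbon. The carbamoyl thus becomes a carboxy. Among the compounds with values here, no measured pair shows this change, so the size of the step is uncertain; a loss of potency beyond the scatter is expected, as an 11-fold higher number from compound 1 to compound 3 (1.06 log units; beyond the scatter). Compound 3 is therefore estimated at 120 nM, within 25 nM to 900 nM.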

Compound 3, half-maximal inhibitory concentration: 5 nM
Beside the measured number, compound 3's estimate is 24-fold (1.38 log units) above it; measured number below the stated range.
By their numbers in this assay, from the lowest: compound 3; then compound 1; then compound 2.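

In this assay, the carbonyl carbon of this side chain accepts hydroxy in place of amino, and the change from carbamoyl to carboxy brings a 2.1-fold lower number from compound 1 to compound 3 (0.32 log units; beyond the scatter). Potency at this position is therefore kept, with a modest gain, so the amino group is not needed for it in this pair. Nothing measured here gives a reason for this step. As far as these compounds go, whether a methyl ester or a methylamide on the same carbonyl carbon would hold this potency remains open. So does whether a longer chain between the core and the carboxy would hold it.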